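A few compounds are considered here, and "the series" means these few. Any claim that something is new, unique, unknown or untested is made for them only; others in the source may bear on it.

Compound 1 `CN1CCC(NC(=O)c2cccc3[nH]cnc23)CC1`: 719 nM
Compound 2 `O=C(NC1CN2CCC1CC2)c1cccc2[nH]cnc12`: > 1000 nM

In an assay on isolated protein for displacement of a labelled ligand from 5-hydroxytryptamine receptor 4 (Rattus norvegicus) (a lower number here means a stronger inhibitor, a higher number a weaker inhibitor), compound 1 gives 719 nM. Compound 2 gives only a limit in this assay, > 1000 nM. Compound 1 thus holds the only number shown. The value of compound 2 sits at the limit of > 1000 nM in this assay, at which 1 of the 2 values shown sits. Compound 3 `CN1CCC(NC(=O)c2cc(Cl)cc3[nH]cnc23)CC1` differs from compound 1 by chloro in place of hydrogen on an aromatic carbon. For the measured compounds named here, no measured pair shows a change of this kind, so the step from compound 1 to compound 3 is estimated as a 2.1-fold lower number from compound 1 to compound 3 (0.31 log units; beyond the scatter), a modest gain close to the scatter. Compound 3 is expected to give about 350 nM, between 120 nM and 1100 nM.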

Compound 3, inhibition constant: 54 nM
For compound 3 the middle estimate is 6.5-fold (0.81 log units) above the measured one; measured number outside the range, below it.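

In this assay chloro in place of hydrogen on this aromatic carbon, meta to a large group, brings a 13-fold lower number from compound 1 to compound 3 (1.12 log units; beyond the scatter) and shows that this position of the core responds strongly to a single chlorine atom. The earlier compounds shown here carried only hydrogen here and said nothing about this position. Nothing given here accounts for the size of this step.

On these data alone, whether fluoro, bromo, methyl or methoxy at this carbon would match chloro stays open. So does the effect of chloro on compound 2, whose > 1000 nM is a limit.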